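Amide aryl substitution pattern in the shared core series

The compounds below may be only part of what the source reports. "The series", "measured", "known", "first", "only" and "open" are said of these compounds alone.

Compound 1, `CC(=O)Nc1cccc2c(-c3cccc(NC(=O)c4ccc(C(F)(F)F)c(Cl)c4)c3)ccnc12`: 7600 nM
Compound 2, `CC(=O)Nc1cccc2c(-c3cccc(NC(=O)c4ccc(Cl)cc4C(F)(F)F)c3)ccnc12`: > 20000 nM

In a functional assay on A375P cells (Homo sapiens) for antiproliferative activity, read by MTT assay, with a stated time of 48 h (on this read-out higher numbers stand for weaker inhibition and lower numbers for stronger inhibition), compound 1 gives 7600 nM. Compound 2 shows only > 20000 nM, which is a limit of the assay (the limit of > 20000 nM in this assay, at which 1 of the 2 values shown sits). Within the data shown here, the single measured step, an at least 2.6-fold higher number from compound 1 to compound 2 (0.42 log units; beyond the scatter), bears on the next change, as compound 3, `CC(=O)Nc1cccc2c(-c3cccc(NC(=O)c4cc(Cl)cc(C(F)(F)F)c4)c3)ccnc12`, again rearranges the same substituents on the amide aryl: 3-chloro-5-(trifluoromethyl)phenyl in place of 4-chloro-2-(trifluoromethyl)phenyl on a carbonyl carbon. Compound 2 stands at the limit, so any numbered value for compound 3 would mean a move in this assay. The expected step is an at least 1.3-fold lower number from compound 2 to compound 3 (0.12 log units; that floor lies within the scatter). Compound 3 is estimated at 15000 nM, with a range from 5000 nM to 40000 nM.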

Compound 3, half-maximal inhibitory concentration: 6200 nM
Compound 3: middle estimate off by 2.4-fold (0.38 log units), on the high side; the measured number falls inside the stated range.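

Rearranging the same two substituents on the amide aryl gives a numbered value in this assay, with an at least 3.2-fold lower number from compound 2 to compound 3 (0.50 log units; beyond the scatter). Compound 2 enters that step only as a limit: the limit of > 20000 nM in this assay, at which 1 of the 3 values shown sits. The 3-chloro-5-(trifluoromethyl)phenyl and 3-chloro-4-(trifluoromethyl)phenyl arrangements are not separated, with a 1.2-fold lower number from compound 1 to compound 3 (0.09 log units; within the scatter), so among these three compounds only the 4-chloro-2-(trifluoromethyl)phenyl amide stands apart.

The compounds shown leave open whether the chlorine alone or the trifluoromethyl alone accounts for this gap. Also open, as far as these compounds go, is how the series responds to a nitrile or an amine on the amide aryl.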